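Ortho chloro on the arylsulfonyl of compound 3

A few compounds are considered here, and "the series" means these few. Any claim that something is new, unique, unknown or untested is made for them only; others in the source may bear on it.

Working notes on a small set. Compound 1 `N#CCNC(=O)[C@@H]1C[C@@H](S(=O)(=O)CC2CC2)C[C@H]1C(=O)N1CCOCC1` gives 230 nM in an assay on isolated protein for inhibition of cathepsin S (Homo sapiens), read by fluorescence, with a stated time of 20 min; a higher number here means a weaker inhibitor, a lower number a stronger inhibitor. Compound 2 `N#CC1(NC(=O)[C@@H]2C[C@@H](S(=O)(=O)c3ccccc3)C[C@H]2C(=O)N2CCS(=O)(=O)CC2)CC1` gives 4 nM in this assay. Compound 3 `N#CC1(NC(=O)[C@@H]2C[C@@H](S(=O)(=O)c3ccccc3)CN2C(=O)c2ccccc2)CC1` gives 13 nM in this assay, the second highest number of the three: compound 2 stands nearest with a lower number and compound 1 furthest with a higher number, both gaps beyond the usual scatter. Compound 4 `N#CC1(NC(=O)[C@@H]2C[C@@H](S(=O)(=O)c3ccccc3Cl)CN2C(=O)c2ccccc2)CC1` is not yet measured. It differs from compound 3 by chloro in place of hydrogen on an aromatic carbon, on an aromatic carbon ortho to a large group. Among the measured compounds shown here, no pair of measured compounds shows this change, so its size cannot be read off; the expected step is none beyond the scatter. Compound 4 is estimated at 10 nM in this assay, between 3 nM and 40 nM. That estimate means an expected step of a 1.3-fold lower number from compound 3 to compound 4 (0.11 log units; within the scatter).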

Compound 4, half-maximal inhibitory concentration: 0.8 nM
For compound 4 the middle estimate is 13-fold (1.10 log units) above the measured one; the measured number lies below the stated range.
By their numbers in this assay, from the lowest: compound 4; then compound 2; then compound 3; then compound 1.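

Chloro in place of hydrogen on an aromatic carbon ortho to a large group gives a 16-fold lower number from compound 3 to compound 4 (1.21 log units; beyond the scatter) in this assay as the first single-place step in this series. Among the compounds shown here, this place on the phenylsulfonyl therefore responds strongly to one chlorine atom, a sensitivity that the earlier compounds could not show. Nothing available accounts for the size of this step.

As far as these compounds go, whether methyl, methoxy or an amine at this place would match chloro remains open, as does the effect of chloro elsewhere on the ring. From the compounds shown here alone, whether the same change carries over to the core of compound 2 also remains open.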